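Ester to amide: a half-life step that cannot be read

The source may hold more compounds than are shown below. What is called first, only, known or untested is meant among the compounds shown, and "the series" means these compounds.

Measured compounds and their values in an ADME assay on microsomes from liver (Homo sapiens) for metabolic stability, read by LC-MS, using NADPH, with stated times of 5 min and 30 min, at 37 degrees C; on this read-out lower numbers stand for a shorter-lived compound and higher numbers for a longer-lived compound:
Compound 1, `C[C@H](O)[C@@H](CCC1CCCCC1)n1cnc2c(N)ncnc21`: in this assay compound 1 gives > 0.5 h; this is a limit of the assay, not a number.
Compound 2, `COC(=O)c1cccc(CC[C@H]([C@H](C)O)n2cnc3c(N)ncnc32)c1`: in this assay compound 2 gives > 0.5 h; this too is a limit.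
Compound 3, `C[C@H](O)[C@@H](CCc1cccc(-c2nccs2)c1)n1cnc2c(N)ncnc21`: in this assay compound 3 gives > 0.5 h; again a limit.

Compound 2 therefore does not stand at a known point; it stands only at the limit of > 0.5 h in this assay, at which 3 of the 3 values shown sit, and so do the two other compounds. Within the data shown here, the one step between measured compounds that differ in a single place, a step that the two limits leave unreadable from compound 2 to compound 3, cannot be read for the same reason, and its size is not known.

The change from compound 2 to compound 4, `CNC(=O)c1cccc(CC[C@H]([C@H](C)O)n2cnc3c(N)ncnc32)c1`, is methylamino in place of methoxy on a carbonyl carbon. Among the measured compounds shown here, no measured step bears on this change with a readable size, so no step in this assay beyond the usual scatter can be expected in either direction; the most likely outcome is that compound 4 is again reported as a limit.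

Compound 4 is estimated to give 1 h in this assay, within 0.5 h to 2 h. The expected step is a step that the limit leaves unreadable from compound 2 to compound 4.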

Compound 4, half-life: > 0.5 h
Compound 4: a limit, no number; the forecaster's own chance of this, stated with the estimate: 75%; the middle value lies beyond the limit too.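

In this assay compound 4 gives > 0.5 h as a limit of the assay, not a number. The steps from compound 2 and from compound 3 to compound 4 cannot be read, because all the values stand at the same point: the limit of > 0.5 h in this assay, at which 4 of the 4 values shown sit.

The compounds shown leave open how long each actually lasts, and so whether methylamino in place of methoxy on a carbonyl carbon changes the half-life at all.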